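Swapping the benzylic headgroup for a furan in compound 4

The compounds below may be only part of what the source reports. "The series", "measured", "known", "first", "only" and "open" are said of these compounds alone.

Measured so far:
compound 1 `NCc1ccc(CN(Cc2nc3ccccc3[nH]2)C2CCCc3cccnc32)c(CN)c1`: 10 nM
compound 2 `COCc1ccc(CN(Cc2nc3ccccc3[nH]2)C2CCCc3cccnc32)c(CN)c1`: 21 nM
compound 3 `NCc1cscc1N(Cc1nc2ccccc2[nH]1)C1CCCc2cccnc21`: 13 nM

Of the compounds shown here, three sharing one core have been tested in a functional assay on CEM-CCRF cells for antagonist activity at C-X-C chemokine receptor type 4 (Homo sapiens), read by calcium flux; a lower number here means a stronger inhibitor, a higher number a weaker inhibitor. Compound 1 gives the lowest of the three numbers; compound 3 sits closest to it, with a gap that lies within the scatter, so no order between them can be claimed. Within the data shown here, compound 2 is the furthest away, and the only single-point step on record, a 2.1-fold higher number from compound 1 to compound 2 (0.32 log units; beyond the scatter), is a modest loss.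

Compound 4 `NCc1occc1CN(Cc1nc2ccccc2[nH]1)C1CCCc2cccnc21` is the next candidate. It differs from compound 1 as follows: a group of 7 heavy atoms (5 carbon, 1 nitrogen, 1 oxygen; one five-membered aromatic ring with 1 hetero atom) in place of a group of 10 heavy atoms (8 carbon, 2 nitrogen; one six-membered aromatic ring of carbon only), on a saturated chain carbon bound to an amine nitrogen. Among the measured compounds shown here, no measured step matches this change exactly. The step from compound 1 to compound 2 concerns a different part of the headgroup and so bears only loosely on it. The values of compound 1 and compound 3 show that a five-membered ring carrying one aminomethyl in this position can sit alongside the bis-substituted ring within the scatter. On that basis the step of a 1.6-fold higher number from compound 1 to compound 4 (0.20 log units; within the scatter) is expected to stay within, or barely beyond, the scatter. Compound 4 is therefore estimated at 16 nM, with a range from 6 nM to 45 nM.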

Compound 4, half-maximal inhibitory concentration: 21 nM
The estimate for compound 4 lay 1.3-fold (0.12 log units) below the measured number; the measured number falls inside the stated range.
By their numbers in this assay, from the lowest: compounds 1, 3, 2 and 4 (each within the scatter of the next, the first and the last beyond it).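

In this assay, the step of a 2.1-fold higher number from compound 1 to compound 4 (0.32 log units; beyond the scatter) shows that exchanging the group on this saturated chain carbon bound to an amine nitrogen costs a modest amount, so a five-membered aromatic ring here does not guarantee a number within the scatter of compound 1. The step of no change at the digits printed from compound 2 to compound 4 (within the scatter) shows that this larger exchange ends level with the methoxy compound. The step of a 1.6-fold higher number from compound 3 to compound 4 (0.21 log units; within the scatter) lies within the scatter, so the oxygen-containing and sulfur-containing five-membered rings cannot be ordered, even though they are attached differently.

The data offered give no explanation for any of these differences. Also open, from the compounds shown here alone, is whether a second aminomethyl group on the five-membered aromatic ring of compound 4 would bring the number back towards that of compound 1.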